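Aryl swap on the shared core: compound 2 to compound 4

A few compounds are considered here, and "the series" means these few. Any claim that something is new, unique, unknown or untested is made for them only; others in the source may bear on it.

In an assay for binding affinity to dual specificity mitogen-activated protein kinase kinase 4 (Homo sapiens), read by KINOMEscan, tested at 100 nM (on this read-out lower numbers stand for a stronger effect and higher numbers for a weaker effect at the one concentration tested), compound 1 `CCCS(=O)(=O)Nc1ccc(F)c(C(=O)c2n[nH]c3ncc(-c4ccccc4C)cc23)c1F` gives 7%, compound 2 `CCCS(=O)(=O)Nc1ccc(F)c(C(=O)c2n[nH]c3ncc(-c4ccc(Cl)c(Cl)c4)cc23)c1F` gives 45% and compound 3 `CCCS(=O)(=O)Nc1ccc(F)c(C(=O)c2n[nH]c3ncc(-c4ccc(S(=O)(=O)NC(C)=O)cc4)cc23)c1F` gives 0.35%. Compound 2 stands highest of the three numbers, beyond the scatter from both compound 1 and compound 3, so it is the weakest binder measured so far. The unmeasured compound 4 `CCCS(=O)(=O)Nc1ccc(F)c(C(=O)c2n[nH]c3ncc(-c4ccc(S(N)(=O)=O)cc4Cl)cc23)c1F` differs from compound 2 in one place: 2-chloro-4-sulfamoylphenyl in place of 3,4-dichlorophenyl on an aromatic carbon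

Within the data shown here, only one measured step alters the same position: a number 38 percentage points higher from compound 1 to compound 2 (beyond the scatter). It shows that the aryl group at this position shifts the read-out by a large amount in this assay. Among the measured compounds shown here, no step is recorded between compound 2 and compound 3, but their two values show compound 3, whose aryl group carries a sulfonamide-type substituent, far lower than compound 2. The entering 2-chloro-4-sulfamoylphenyl keeps one chlorine of the leaving group and adds a sulfamoyl substituent, so compound 4 is expected to move toward the low value of compound 3, with a number 39 percentage points lower from compound 2 to compound 4 (beyond the scatter) as the expected downward step, beyond the scatter. For compound 4 the estimated value in this assay is 6%, within 0.5% to 25%.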

Compound 4, a percentage reported as activity, at one concentration (the size of the read-out at that concentration, not a potency): 3.4%
For compound 4 the middle estimate is 2.6 percentage points above the measured one; the range from low to high includes it.
By their numbers in this assay, from the lowest: compounds 3, 4 and 1 (each within the scatter of the next); then compound 2.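

Working notes on the aryl position: in this assay, 2-chloro-4-sulfamoylphenyl in place of 3,4-dichlorophenyl brings a large downward step (a number 41.6 percentage points lower from compound 2 to compound 4 (beyond the scatter)), so keeping one chlorine on the aryl group does not keep the high number of compound 2. Against 2-methylphenyl, the same group gives no separable change (a number 3.6 percentage points lower from compound 1 to compound 4 (within the scatter)); compound 3, compound 4 and compound 1 each lie within the scatter of the next, so at this one concentration the read-out does not order these three aryl groups, and only compound 2 stands apart from them. Nothing available explains why the sulfamoyl-bearing group and the dichlorophenyl group differ so widely on this read-out.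

The compounds shown leave open whether the sulfamoyl group would give a similarly low number on an aryl group carrying no chlorine, and whether the chlorine contributes anything to compound 4. They also leave open how a carboxylic acid or a primary amine in place of the sulfamoyl group would read in this assay.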